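Shifting a methyl from 2-methylphenyl to 3-methylphenyl

A few compounds are considered here, and "the series" means these few. Any claim that something is new, unique, unknown or untested is made for them only; others in the source may bear on it.

compound 1, `Cc1ccccc1Nc1nc(C)c(C(=O)/C=C/c2ccc(Cl)cc2)s1`, > 25000 nM
compound 2, `COc1cc(/C=C/C(=O)c2sc(Nc3ccccc3C)nc2C)cc(OC)c1OC`, 6320 nM
compound 3, `Cc1cccc(Nc2nc(C)c(C(=O)/C=C/c3ccc(Cl)cc3)s2)c1`, > 25000 nM

Of the compounds shown here, three have been tested in a functional assay on NCI-H460 cells (Homo sapiens) for cytotoxicity, read by MTT assay; a lower number here means a stronger inhibitor, a higher number a weaker inhibitor. Compound 1 reaches only a limit of the assay, > 25000 nM. Compound 3 likewise returns only a limit, > 25000 nM. Among the compounds with values here, compound 2 gives 6320 nM, the single number among the three. Compound 3 differs from compound 1 by 3-methylphenyl in place of 2-methylphenyl on a nitrogen on an aromatic ring, and the resulting step, a step that the two limits leave unreadable from compound 1 to compound 3, has no readable size. The difference between the cores of compound 1 and compound 2 is not broken down here.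

Compound 4, `COc1cc(/C=C/C(=O)c2sc(Nc3cccc(C)c3)nc2C)cc(OC)c1OC`, differs from compound 2 by 3-methylphenyl in place of 2-methylphenyl on a nitrogen on an aromatic ring, the same change as between compound 1 and compound 3. Within the data shown here, the one measured instance of this change gives no usable size, and two of the three values sit at the limit, (the limit of > 25000 nM in this assay, at which 2 of the 3 values shown sit). The step from compound 2 to compound 4 is therefore expected to be small, a 1.1-fold higher number from compound 2 to compound 4 (0.04 log units; within the scatter), with a real chance that compound 4 itself returns only a limit. Compound 4 is estimated at 7000 nM, within 2500 nM to 25000 nM.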

Compound 4, half-maximal inhibitory concentration: 19800 nM
The estimate for compound 4 lay 2.8-fold (0.45 log units) below the measured number; low and high end bracket the measured number.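

In this assay, the change from 2-methylphenyl to 3-methylphenyl on the core of compound 2 gives a 3.1-fold higher number from compound 2 to compound 4 (0.50 log units; beyond the scatter), a modest weakening that can be read. The same change on the core of compound 1 has no readable size, since compound 1 and compound 3 both return a limit of the assay and not a number: the limit of > 25000 nM in this assay, at which 2 of the 4 values shown sit. The series therefore offers one sized instance of this change and no second one to set against it, so the result neither confirms nor contradicts that the change carries the same size from one core to another.

The compounds shown leave open what an amine or a carboxylic acid in place of the methyl of the 3-methylphenyl would do on either core. Also open, going by these compounds, is whether any close relative on the core of compound 1 would return a number in this assay, which would let the step be sized there.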